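A few compounds are considered here, and "the series" means these few. Any claim that something is new, unique, unknown or untested is made for them only; others in the source may bear on it.

Compound 1 `CCn1c(C(=O)NCCCN(C)C)ccc1C(CC)(CC)c1ccc(OCC(O)C(C)(C)C)c(C)c1` gives 360 nM in a functional assay on HepG2 cells (Homo sapiens), read by MTT assay, with a stated time of 48 h (on this read-out higher numbers stand for weaker inhibition and lower numbers for stronger inhibition), the second highest of the three numbers measured here. Compound 2 `CC[C@@H](C)[C@H](NC(=O)c1ccc(C(CC)(CC)c2ccc(OCC(=O)C(C)(C)C)c(C)c2)n1CC)C(=O)O` gives 247 nM, which lies within the scatter of compound 1, while compound 3 `CCn1c(C(=O)N(C)CC(=O)O)ccc1C(CC)(CC)c1ccc(OCC(=O)C(C)(C)C)c(C)c1` gives 25200 nM. Among the compounds with values here, the single measured step, a 100-fold higher number from compound 2 to compound 3 (2.01 log units; beyond the scatter), shows that what sits on this carbonyl carbon can move the number a great deal. Compound 4 `CCn1c(C(=O)OCc2ccc(F)cc2)ccc1C(CC)(CC)c1ccc(OCC(O)C(C)(C)C)c(C)c1` differs from compound 1 by (4-fluorobenzyl)oxy in place of (3-(dimethylamino)propyl)amino on a carbonyl carbon. Within the data shown here, no measured step matches this exchange, so the direction cannot be read from the data; the one known step only warns that a large move in either direction is possible. The number expected for compound 4 is 1000 nM, with a range from 150 nM to 8000 nM. This expectation amounts to an estimated 2.8-fold higher number from compound 1 to compound 4 (0.44 log units; beyond the scatter).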

Compound 4, half-maximal inhibitory concentration: > 50000 nM
Compound 4: a limit, no number; the forecaster's own chance of this, stated with the estimate: 5%; at least 50-fold (1.69 log units) between middle value and limit.
By their numbers in this assay, from the lowest: compounds 2 and 1 (each within the scatter of the next); then compound 3. At a limit, above all of these: compound 4.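

In this assay, compound 4 gives no number but a limit of the assay, > 50000 nM. Placing (4-fluorobenzyl)oxy in place of (3-(dimethylamino)propyl)amino on this carbonyl carbon gives an at least 130-fold higher number from compound 1 to compound 4 (2.14 log units; beyond the scatter). Within the data shown here, the only earlier step exchanged one amino group for another, whereas this one shows that a group joined through oxygen can also produce a large move, here toward weaker inhibition.

This single exchange alters both the linking atom and the chain at once, so the two effects remain unseparated. A (4-fluorobenzyl)amino group on the same carbonyl carbon would tell them apart.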